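This account rests on a few compounds, and the source may have more. Where it says the series, first, only, none or still open, it means among the compounds named here.

Measured so far:
compound 1 `O=C1/C(=C/c2ccc(O)cc2)Cc2ccccc2/C1=C\c1ccc([N+](=O)[O-])cc1` — 2500 nM
compound 2 `COc1ccc(/C=C2\CC/C(=C\c3ccc([N+](=O)[O-])cc3)C2=O)cc1` — > 400000 nM

Among the compounds with values here, in a functional assay on HL-60 cells (Homo sapiens) for cytotoxicity (on this read-out higher numbers stand for lower toxicity in this test and lower numbers for higher toxicity in this test), compound 1 gives 2500 nM, the only number in hand. For compound 2 the result is a limit of the assay, > 400000 nM, and not a number. This is noted as the limit of > 400000 nM in this assay, at which 1 of the 2 values shown sits. On these data alone, compound 3 `COc1ccc(/C=C2\Cc3ccccc3/C(=C\c3ccc([N+](=O)[O-])cc3)C2=O)cc1OC` is untested. It differs from compound 1 by 3,4-dimethoxyphenyl in place of 4-hydroxyphenyl on a double-bonded chain carbon bound to a double-bonded ring carbon. Within the data shown here, no step between measured compounds is available to size this change. Compound 3 is expected to show a step of a 2.8-fold higher number from compound 1 to compound 3 (0.45 log units; beyond the scatter), a loss beyond the scatter, toward lower toxicity. The estimate for compound 3 is 7000 nM, within 1500 nM to 40000 nM.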

Compound 3, half-maximal cytotoxic concentration: 560 nM
The estimate for compound 3 lay 13-fold (1.10 log units) above the measured number; the measured number lies below the stated range.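

In this assay, 3,4-dimethoxyphenyl in place of 4-hydroxyphenyl on a double-bonded chain carbon bound to a double-bonded ring carbon gives a 4.5-fold lower number from compound 1 to compound 3 (0.65 log units; beyond the scatter), toward higher toxicity in this test. This place therefore responds to substitution, and 1 hydrogen-bond donor on the leaving group is not required for cytotoxicity on the core of compound 1. No measured property bears on the size or direction of this step.

On these data alone, the step swaps the hydroxyl for two methoxy groups at once, so their separate contributions remain open. Also open, as far as these compounds go, is how an amine or a carboxylic acid on this phenyl ring would read.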